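Bromo for Chloro Across Two Related Cores

The source may report more compounds than this note shows. Statements on the series, on what has been measured and on what is new or still open speak of the compounds shown alone.

Compound 1 `Clc1ccc(CSc2nnc(-c3cnccn3)o2)cc1` and compound 2 `Brc1ccc(CSc2nnc(-c3cnccn3)o2)cc1` share one core, while compound 3 `Clc1ccc(CSc2nnc(-c3cnccn3)n2-c2ccccc2)cc1` and compound 4 `Brc1ccc(CSc2nnc(-c3cnccn3)n2-c2ccccc2)cc1` share another. The difference between the two cores is not broken down here. In a functional assay on HeLa cells (Homo sapiens) for antiproliferative activity, read by MTT assay, with a stated time of 48 h (on this read-out lower numbers stand for stronger inhibition and higher numbers for weaker inhibition), compound 1 gives 24600 nM. In this assay compound 2 gives 21600 nM. The change from compound 1 to compound 2 is bromo in place of chloro on an aromatic carbon, and it gave a 1.1-fold lower number from compound 1 to compound 2 (0.06 log units; within the scatter).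

In this assay compound 3 gives only > 50000 nM, which is a limit of the assay and not a number. This is the limit of > 50000 nM in this assay, at which 1 of the 3 values shown sits.

Compound 4 differs from compound 3 by bromo in place of chloro on an aromatic carbon. The place of the change is the same, word for word, as in the earlier pair, so it is the same change. Because the measured pair gave a 1.1-fold lower number from compound 1 to compound 2 (0.06 log units; within the scatter), the same change is expected to move the number little here as well. Because compound 3 sits at > 50000 nM, compound 4 is expected to remain at or near the limit. The expected step is a number no higher from compound 3 to compound 4 (the limit leaves the size open). Compound 4 is estimated at 50000 nM, within a range from 25000 nM to 100000 nM.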

Compound 4, half-maximal inhibitory concentration: 8630 nM
Beside the measured number, compound 4's estimate is 5.8-fold (0.76 log units) above it; measured number outside the range, below it.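

In this assay, bromo in place of chloro on an aromatic carbon gave an at least 5.7-fold lower number from compound 3 to compound 4 (0.76 log units; beyond the scatter), so the small step seen on the core of compound 1 did not carry over in size to the core of compound 3: the same change on two cores in this assay, a 1.1-fold lower number (0.06 log units; within the scatter) from compound 1 to compound 2 and an at least 5.7-fold lower number (0.76 log units; beyond the scatter) from compound 3 to compound 4, at least 5.0-fold (0.70 log units) apart, beyond the scatter of two such steps. On these data alone, compound 3 gives > 50000 nM, which is a limit of the assay and not a number, so only the least size of the step is known and its true size stays open: the limit of > 50000 nM in this assay, at which 1 of the 4 values shown sits. The comparison rests on one pair on each core, and it does not show why the two cores differ or whether a further core would follow either of them.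

The compounds shown carry only chloro or bromo at this place, which leaves open how fluoro or an amine there would behave in this assay. Also open, as far as these compounds go, is how either core would respond with a longer chain in place of the 4-bromobenzyl group.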